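Methylsulfonyl for Acetamido at a Second Ring Position

The source may hold more compounds than are shown below. What is called first, only, known or untested is meant among the compounds shown, and "the series" means these compounds.

Compound 1 `CC(=O)Nc1cccc(OCc2cc(C)nc(-c3ccccn3)n2)c1` and compound 2 `CC(=O)Nc1ccc(OCc2cc(C)nc(-c3ccccn3)n2)cc1` are built from the same atoms joined differently; the difference between the two cores is not broken down here. In a physicochemical assay for lipophilicity, at pH 7.4 (on this read-out lower numbers stand for lower lipophilicity and higher numbers for higher lipophilicity), compound 1 gives 2.1, and compound 2 gives 1.9, two numbers that lie within the scatter of each other. Compound 3 `Cc1cc(COc2cccc(S(C)(=O)=O)c2)nc(-c2ccccn2)n1` carries the change methylsulfonyl in place of acetamido on an aromatic carbon relative to compound 1, with the incoming group meta to a large group, and in this assay compound 3 gives 1.7. The resulting step, a number 0.40 log units lower from compound 1 to compound 3 (beyond the scatter), is the only one among the three measured compounds that exceeds the scatter.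

Compound 4 `Cc1cc(COc2ccc(S(C)(=O)=O)cc2)nc(-c2ccccn2)n1` has not been measured yet. It relates to compound 2 through (methylsulfonyl in place of acetamido on an aromatic carbon). Here the incoming group stands para to a large group, whereas in compound 3 it stands meta to a large group, so the two changes are the same kind of change rather than the same change. Compound 2 and compound 3 differ only within the scatter, so the two changes begin from alike starting points. For compound 4 a step of about a number 0.40 log units lower from compound 2 to compound 4 (beyond the scatter) in this assay is expected, resting on the measured step of a number 0.40 log units lower from compound 1 to compound 3 (beyond the scatter). Compound 4 is therefore estimated at 1.5, with a likely range from 1.2 to 1.8.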

Compound 4, distribution coefficient: 1.5
For compound 4 middle estimate and measured number coincide at the digits printed; the range from low to high includes it.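

In this assay, methylsulfonyl in place of acetamido, with the incoming group para to a large group, gives a number 0.40 log units lower from compound 2 to compound 4 (beyond the scatter) and so matches in printed size the earlier a number 0.40 log units lower from compound 1 to compound 3 (beyond the scatter) on the core of compound 1. The change therefore carried from one core to the other in this series with its direction and size intact, and each of these pairs lies beyond the scatter, although each step is modest. This rests on only these pairs and supports no general rule for other cores, other ring positions or other read-outs, and nothing measured here accounts for the agreement between the steps.

The compounds shown leave open whether an amine or a carboxylic acid in place of acetamido would give a step of matching size on both cores, and whether a longer chain, such as ethylsulfonyl in place of methylsulfonyl, would do the same. They also leave open whether the step would keep its size on a third core, where the starting number might lie further from those of the cores compared here.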